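Swapping the Aryl Group on a Fused Ring Amide

The compounds below may be only part of what the source reports. "The series", "measured", "known", "first", "only" and "open" are said of these compounds alone.

Compound 2 `COc1ccc(N2C(=O)[C@H]3[C@H](ON4[C@@H]3C(=O)N(C)[C@@]43C[C@H](C)CC[C@H]3C(C)C)C2=O)cc1` gives 75.1% in a functional assay, read by spectrophotometry, with a stated time of 2 h, tested at 3 mg/mL; a higher number here means a stronger effect of the compound at the concentration tested, a lower number a weaker effect. Within the data shown here, the only other compound with a number, compound 1 `CC(C)[C@@H]1CC[C@@H](C)C[C@@]12N(C)C(=O)[C@@H]1[C@H]3C(=O)N(c4ccccc4)C(=O)[C@H]3ON12`, gives 73.5% in this assay, and the step of a number 1.6 percentage points higher from compound 1 to compound 2 (within the scatter) means the two cannot be told apart. Compound 3 `Cc1cccc(N2C(=O)[C@H]3[C@H](ON4[C@@H]3C(=O)N(C)[C@@]43C[C@H](C)CC[C@H]3C(C)C)C2=O)c1` is the next variant: 3-methylphenyl in place of 4-methoxyphenyl on an amide-type nitrogen in a ring. Among the measured compounds shown here, the sole measured step touches a different part of that aromatic ring and stayed within the scatter, so for compound 3 the expectation is a step of a number 3.1 percentage points lower from compound 2 to compound 3 (within the scatter) with no clear direction. Compound 3 is estimated at 72%, between 60% and 84%.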

Compound 3, a percentage reported as activity, at one concentration (the size of the read-out at that concentration, not a potency): 52.4%
Beside the measured number, compound 3's estimate is 19.6 percentage points above it, outside the stated range (below it).
By their numbers in this assay, from the lowest: compound 3; then compounds 1 and 2 (each within the scatter of the next).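

This position is not as tolerant as the first two compounds suggested: 3-methylphenyl in place of 4-methoxyphenyl gives a number 22.7 percentage points lower from compound 2 to compound 3 (beyond the scatter) in this assay. A single methyl in place of hydrogen on the aromatic ring likewise gives a number 21.1 percentage points lower from compound 1 to compound 3 (beyond the scatter), so a small change on this ring can produce a step beyond the scatter. Nothing available explains this loss. From the compounds shown here alone, it remains open how a chlorine or an amine on the same aromatic ring would read in this assay, and whether a pyridine ring could stand in place of the phenyl ring.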